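Swapping Aromatic Groups on an Ester of a Shared Core

This account rests on a few compounds, and the source may have more. Where it says the series, first, only, none or still open, it means among the compounds named here.

Compound 2 `CC1=CC[C@H](C(C)C)c2cc(C)c(OC(=O)Nc3ccccc3)cc21`, compound 3 `CC1=CC[C@H](C(C)C)c2cc(C)c(OC(=O)c3cccc(C)c3)cc21` and compound 1 `COc1cccc(C(=O)Oc2cc3c(cc2C)[C@@H](C(C)C)CC=C3C)c1` share one core and differ only in the group attached through a carbonyl. In a functional assay on HCT-15 cells (Homo sapiens) for antiproliferative activity, read by sulforhodamine B assay, with a stated time of 48 h, tested at 50 uM (a lower number here means less inhibition, a higher number more inhibition at the concentration tested (going by the name of the read-out)), compound 2 gives 92%, compound 3 gives 5.3% and compound 1 gives "not active" (no number reported). Among the compounds with values here, the one step between compounds with numbers, a number 86.7 percentage points lower from compound 2 to compound 3 (beyond the scatter), is large, and compound 3 holds the lower of the two numbers. Compound 4 `COc1ccc(C(=O)Oc2cc3c(cc2C)[C@@H](C(C)C)CC=C3C)cc1` differs from compound 3 by 4-methoxyphenyl in place of 3-methylphenyl on a carbonyl carbon. Within the data shown here, no measured step covers this exact change; the only step measured concerns a different pair, and compound 1, which also carries an aromatic group on the carbonyl carbon, is reported as not active. A step of about a number 0.7 percentage points higher from compound 3 to compound 4 (within the scatter) is therefore expected, within the scatter. Compound 4 is estimated at 6%, between 0% and 20%.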

Compound 4, a percentage reported as inhibition, at one concentration (the size of the read-out at that concentration, not a potency): 30.8%
Compound 4: the middle estimate sits 24.8 percentage points below what was measured; the measured number lies above the stated range.
By their numbers in this assay, from the lowest: compound 3; then compound 4; then compound 2.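

In this assay, the choice of aromatic group on this carbonyl carbon matters even among the esters: 4-methoxyphenyl in place of 3-methylphenyl gives a number 25.5 percentage points higher from compound 3 to compound 4 (beyond the scatter). That gain still leaves the ester well short of the anilino compound, with a number 61.2 percentage points lower from compound 2 to compound 4 (beyond the scatter). Nothing available here explains the difference between these groups.

The compounds shown leave open how a longer alkyl chain or an aminophenyl group on the same carbonyl carbon would compare, and whether either would approach compound 2.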